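From ethoxy to isopropoxy: a small step expected

The source may hold more compounds than are shown below. What is called first, only, known or untested is meant among the compounds shown, and "the series" means these compounds.

In a functional assay on HCT-116 cells (Homo sapiens) for inhibition, read by MTT assay, with a stated time of 72 h, in the presence of a further agent that is not named here (on this read-out higher numbers stand for an effect only at larger amounts of compound and lower numbers for an effect already at smaller amounts), compound 1 (`O=C(Nc1ccnc(Cl)c1)Nc1cc(Cl)nc(Cl)c1`) reads 16100 nM and compound 2 (`COc1cc(NC(=O)Nc2cc(Cl)nc(Cl)c2)cc(Cl)n1`), which adds methoxy, reads 11200 nM while compound 3 (`CCOc1cc(NC(=O)Nc2cc(Cl)nc(Cl)c2)cc(Cl)n1`), which adds ethoxy instead, reads 6130 nM on the same scale. Compound 3 thus stands clearly apart from compound 1 but within the scatter of compound 2.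

Compound 4 (`CC(C)Oc1cc(NC(=O)Nc2cc(Cl)nc(Cl)c2)cc(Cl)n1`) takes the chain one stage further, from ethoxy to isopropoxy. The difference is methyl in place of hydrogen on a saturated chain carbon bound to an oxygen on an aromatic ring and a saturated chain carbon.

Going by the values given here, the closest precedent is the methyl added in going from methoxy to ethoxy, which gave a 1.8-fold lower number from compound 2 to compound 3 (0.26 log units; within the scatter) as its result. Adding the oxygen-linked groups to the hydrogen-bearing carbon gave a 1.4-fold lower number from compound 1 to compound 2 (0.16 log units; within the scatter) for methoxy and a 2.6-fold lower number from compound 1 to compound 3 (0.42 log units; beyond the scatter) for ethoxy, and only the latter lies beyond the scatter. No branched chain has been measured yet, so this precedent is only a rough guide. In this assay the expected step is a 1.3-fold lower number from compound 3 to compound 4 (0.11 log units; within the scatter) and thus none beyond the scatter. The estimated value for compound 4 is 4800 nM with an expected span from 2300 nM to 10500 nM as its range.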

Compound 4, half-maximal effective concentration: 5230 nM
For compound 4 the middle estimate is 1.1-fold (0.04 log units) below the measured one; the measured number falls inside the stated range.
By their numbers in this assay, from the lowest: compounds 4, 3, 2 and 1 (each within the scatter of the next, the first and the last beyond it).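

Going by these compounds alone, the isopropoxy group is the first branched chain at this position, and in this assay the branch cannot be told apart from the unbranched ethoxy group, with a 1.2-fold lower number from compound 3 to compound 4 (0.07 log units; within the scatter). Its weight shows instead against the smaller groups: on the oxygen on the aromatic ring, isopropyl in place of methyl gives a 2.1-fold lower number from compound 2 to compound 4 (0.33 log units; beyond the scatter), which passes the scatter, whereas the ethyl in place of methyl gave a 1.8-fold lower number from compound 2 to compound 3 (0.26 log units; within the scatter), which did not, and isopropoxy in place of hydrogen gives a 3.1-fold lower number from compound 1 to compound 4 (0.49 log units; beyond the scatter), the largest step in the set so far. Nothing measured in this set gives a cause for these steps.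

The compounds shown leave open whether a longer chain such as butoxy, or a ring such as cyclopropylmethoxy, on this oxygen would move the number further or whether the series has flattened out at ethoxy and isopropoxy. They also leave open how an amine in place of the oxygen-linked group would read at this position, since every substituted compound here carries its chain through an oxygen.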